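The compounds below may be only part of what the source reports. "The series", "measured", "known", "first", "only" and "open" are said of these compounds alone.

Measured in a functional assay on DU-145 cells (Homo sapiens) for inhibition, read by MTT assay, with a stated time of 24 h; a lower number here means a stronger inhibitor, a higher number a weaker inhibitor:
- compound 1 `CCCCCCCCn1cc(COC2(C(F)(F)F)Oc3ccccc3C=C2C(=O)OCC)nn1`: > 150000 nM, a limit of the assay, not a number.
- compound 2 `CCOC(=O)C1=Cc2ccccc2OC1(OCc1cc(-c2ccc(OC)cc2)no1)C(F)(F)F`: > 150000 nM, likewise a limit.
- compound 3 `O=C(O)C1=Cc2ccccc2OC1(OCc1cc(-c2ccc3ccccc3c2)no1)C(F)(F)F`: 141000 nM.

Compound 1 stands at the upper boundary of this assay: no number is known for it, only that it lies beyond the range measured. Two of the three values in the set sit at the limit of > 150000 nM in this assay, at which 2 of the 3 values shown sit. Among the compounds with values here, compound 3 gives the only actual number, and that number lies close to the same boundary. No two measured compounds differ in a single place, so no single step is shown.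

Compound 4 `CCOC(=O)C1=Cc2ccccc2OC1(OCc1cn(CC(=O)Nc2ccccc2F)nn1)C(F)(F)F` is not yet measured. It differs from compound 1 in one place: (2-fluorophenyl)carbamoyl in place of heptyl on a saturated chain carbon bound to an aromatic nitrogen. Within the data shown here, with compound 1 known only as a limit in this assay, and the one number in the set, that of compound 3, close to that limit, the step is expected to be none beyond the scatter, with no direction to be inferred. Compound 4 is expected near 150000 nM in this assay, within 60000 nM to 400000 nM. The step this estimate means is a number no higher from compound 1 to compound 4 (the limit leaves the size open), an expectation only, and a limit rather than a number is as likely as not.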

Compound 4, half-maximal inhibitory concentration: 33900 nM
Compound 4: middle estimate off by 4.4-fold (0.65 log units), on the high side; the measured number lies below the stated range.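

In this assay, (2-fluorophenyl)carbamoyl in place of heptyl on a saturated chain carbon bound to an aromatic nitrogen gives an at least 4.4-fold lower number from compound 1 to compound 4 (0.64 log units; beyond the scatter). Compound 1 gives > 150000 nM, which is a limit of the assay and not a number, so the step has no upper size. This position therefore bears on the read-out, which the earlier compounds, at or close to the limit, could not show: the limit of > 150000 nM in this assay, at which 2 of the 4 values shown sit.

The change brings in the aromatic ring, the amide hydrogen, the carbonyl and the fluorine together, and the compounds shown do not separate their shares in the step. On these data alone, whether a plain phenylcarbamoyl, without the fluorine, or a benzyl group at the same place would keep the step remains open.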